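The source may hold more compounds than are shown below. What is called first, only, known or untested is meant among the compounds shown, and "the series" means these compounds.

Compound 1 `COc1ccc(C(=O)/C=C/c2cc(-c3cc(OC)c(OC)c(OC)c3)n[nH]2)cc1OC`: 1330 nM
Compound 2 `COc1cc(-c2cc(/C=C/C(=O)c3ccc(F)c(F)c3)[nH]n2)cc(OC)c1OC`: 2290 nM

Among the compounds with values here, in a functional assay on TK-10 cells (Homo sapiens) for inhibition, read by sulforhodamine B assay, with a stated time of 48 h (on this read-out lower numbers stand for stronger inhibition of growth and higher numbers for weaker inhibition of growth), compound 1 gives 1330 nM, and compound 2 sits alongside it: the one measured step, a 1.7-fold higher number from compound 1 to compound 2 (0.24 log units; within the scatter), stays within the scatter. Compound 3 `COc1cc(C(=O)/C=C/c2cc(-c3cc(OC)c(OC)c(OC)c3)n[nH]2)cc(OC)c1OC` keeps the shared core and differs from compound 1 by methoxy in place of hydrogen on an aromatic carbon. Within the data shown here, that measured step swaps the whole ring on the carbonyl carbon for another, whereas the change to compound 3 adds a group to that ring, so no measured step bears directly on it. The expectation is therefore no step beyond the scatter, no change at the digits printed from compound 1 to compound 3 (within the scatter). Compound 3 is estimated at 1330 nM, ranging from 500 nM to 3500 nM.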

Compound 3, concentration for 50% growth inhibition: 1460 nM
Estimate against measurement, compound 3: 1.1-fold (0.04 log units) below, and the stated range covers the measured number.
By their numbers in this assay, from the lowest: compounds 1, 3 and 2 (each within the scatter of the next).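

In this assay the swap of methoxy for hydrogen gives a 1.1-fold higher number from compound 1 to compound 3 (0.04 log units; within the scatter) and so the ring on the carbonyl carbon accepts one more methoxy group, at a place ortho to a methoxy group and meta to a large group, without a step beyond the scatter. Nothing measured here bears on what the added group does at this position. What the compounds shown leave open is whether an amine or a carboxylic acid at this same carbon would also stay within the scatter, and whether a longer chain such as butoxy would.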